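The source may hold more compounds than are shown below. What is called first, only, known or untested is meant among the compounds shown, and "the series" means these compounds.

Of the compounds shown here, two have numbers so far. In an assay on membranes from HEK293 cells for displacement of a labelled ligand from adenosine receptor A2b (Homo sapiens), read by scintillation counting, with a stated time of 30 min (a higher number here means a weaker inhibitor, a lower number a stronger inhibitor), compound 1 `CC1=C(C(=O)OCc2ccccc2)C(c2ccco2)NC(=O)N1` gives 887 nM, and compound 2 `CC1=C(C(=O)OCC(C)C)C(c2ccoc2)NC(=O)N1` gives 326 nM. Compound 2 thus holds the lower of the two numbers, with compound 1 at a gap that is beyond the usual scatter; the two differ in two places at once, so the gap is not traceable to either change alone. Compound 3 `CC1=C(C(=O)OCc2ccccc2)C(c2ccoc2)NC(=O)N1` is not yet measured in this assay. Relative to compound 2 the change is phenyl in place of isopropyl on a saturated chain carbon bound to an oxygen next to a carbonyl group, which read one bond further out is isobutyl to benzyl; the ester of compound 3 is the one carried by compound 1. Going by the values given here, no single-change step is available, so the expected step of a 1.5-fold higher number from compound 2 to compound 3 (0.19 log units; within the scatter) in this assay is a modest weakening, near or at the edge of the scatter. Compound 3 is estimated in this assay at 500 nM, within 200 nM to 1300 nM.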

Compound 3, inhibition constant: 6650 nM
The estimate for compound 3 lay 13-fold (1.12 log units) below the measured number; the measured number lies above the stated range.
By their numbers in this assay, from the lowest: compound 2; then compound 1; then compound 3.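

With furan-3-yl held fixed in this assay, phenyl in place of isopropyl on a saturated chain carbon bound to an oxygen next to a carbonyl group, read one bond further out as isobutyl to benzyl, gives a 20-fold higher number from compound 2 to compound 3 (1.31 log units; beyond the scatter) and is a large loss at the ester, which the earlier pair could not separate from the furan change. With the benzyl ester held fixed, furan-3-yl in place of furan-2-yl on a saturated ring carbon gives a 7.5-fold higher number from compound 1 to compound 3 (0.87 log units; beyond the scatter) and is a modest loss, so the furan attachment also matters in this ester series. Nothing at hand bears on the cause of either step.

Open, on these data alone, is whether the furan-2-yl and furan-3-yl difference keeps its direction and size with the isobutyl ester. Also open, as far as these compounds go, is how a longer chain, a cyclohexylmethyl ester or an amide in place of the ester would read at this position.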